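The source may report more compounds than this note shows. Statements on the series, on what has been measured and on what is new or still open speak of the compounds shown alone.

In a functional assay on HepG2 cells (Homo sapiens) for cytotoxicity, read by MTT assay (a lower number here means a stronger inhibitor, a higher number a weaker inhibitor), compound 1 (`COc1ccc(/C=C/C(=O)c2ccc(OC)c3c2OC(C)(C)C=C3)cc1OC(=O)CCl`) gives 120 nM and compound 2 (`COc1ccc(/C=C/C(=O)c2ccc(OC)c3c2OC(C)(C)C=C3)cc1OC(=O)C1CC1`) gives 220 nM, while compound 3 (`COc1cccc(C(=O)Oc2cc(/C=C/C(=O)c3ccc(OC)c4c3OC(C)(C)C=C4)ccc2OC)c1`) stands highest of the three at 870 nM on this read-out. Compound 4 (`COc1ccc(/C=C/C(=O)c2ccc(OC)c3c2OC(C)(C)C=C3)cc1OC(=O)c1ccco1`) carries furan-2-yl in place of 3-methoxyphenyl on a carbonyl carbon and is otherwise unchanged. Bringing in 3-methoxyphenyl gave a 4.0-fold higher number from compound 2 to compound 3 (0.60 log units; beyond the scatter) and a 7.3-fold higher number from compound 1 to compound 3 (0.86 log units; beyond the scatter) as modest steps, whereas cyclopropyl in place of chloromethyl gave only a 1.8-fold higher number from compound 1 to compound 2 (0.26 log units; within the scatter) in the same position. No furan-2-yl ester has been measured, so the data give only a rough guide. Removing 3-methoxyphenyl is therefore expected to give a modest fall in the number, an estimated 2.2-fold lower number from compound 3 to compound 4 (0.34 log units; beyond the scatter) in this assay on this basis. Compound 4 is estimated at 400 nM (range 150 nM to 1000 nM).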

Compound 4, half-maximal inhibitory concentration: 370 nM
The estimate for compound 4 lay 1.1-fold (0.03 log units) above the measured number; the measured number falls inside the stated range.
By their numbers in this assay, from the lowest: compounds 1, 2 and 4 (each within the scatter of the next, the first and the last beyond it); then compound 3.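

In this assay, furan-2-yl shows that a ring on this carbonyl carbon need not carry the full penalty seen with 3-methoxyphenyl, giving a 2.4-fold lower number from compound 3 to compound 4 (0.37 log units; beyond the scatter). The step to furan-2-yl from cyclopropyl stays within the scatter, at a 1.7-fold higher number from compound 2 to compound 4 (0.23 log units; within the scatter), whereas the step from chloromethyl lies beyond it, at a 3.1-fold higher number from compound 1 to compound 4 (0.49 log units; beyond the scatter). Nothing available explains these differences. The compounds shown leave open whether the difference between the two aromatic rings comes from ring size or from the methoxy group, and how a chain carrying an amine would behave on this carbonyl carbon.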